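A few compounds are considered here, and "the series" means these few. Any claim that something is new, unique, unknown or untested is made for them only; others in the source may bear on it.

In an ADME assay on S9 fraction from liver (Rattus norvegicus) for metabolic stability, with a stated time of 1 h (on this read-out lower numbers stand for a less stable compound and higher numbers for a more stable compound), compound 1 `N#Cc1cnc(NCc2cnccc2C(F)(F)F)cc1N[C@H]1C[C@H](O)C1`, with 3-hydroxycyclobutyl on a nitrogen on an aromatic ring, gives 82%. With 4-hydroxycyclohexyl in that place, compound 2 `N#Cc1cnc(NCc2cnccc2C(F)(F)F)cc1N[C@H]1CC[C@@H](O)CC1` gives 6% and compound 3 `N#Cc1cnc(NCc2cnccc2C(F)(F)F)cc1N[C@H]1CC[C@H](O)CC1` gives 25%. Compound 3 therefore stands second of the three, beyond the scatter from both neighbours.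

Compound 4 `N#Cc1cnc(NCc2cnccc2C(F)(F)F)cc1NC[C@H]1CC[C@@H](O)CC1` carries (4-hydroxycyclohexyl)methyl in place of 4-hydroxycyclohexyl on the same nitrogen: (4-hydroxycyclohexyl)methyl in place of 4-hydroxycyclohexyl on a nitrogen on an aromatic ring. Within the data shown here, no measured step makes this exact change. The closest guides are the large ring changes, a number 76 percentage points lower from compound 1 to compound 2 (beyond the scatter) and a number 57 percentage points lower from compound 1 to compound 3 (beyond the scatter). The modest a number 19 percentage points higher from compound 2 to compound 3 (beyond the scatter) can be traced only to the fact that compounds 2 and 3 differ only in the configuration as drawn.

The six-membered ring stays, so the value in this assay is expected to remain in the low range set by the two cyclohexyl compounds, not to return towards the cyclobutyl value. The expected change is small and downward, a number 9 percentage points lower from compound 3 to compound 4 (within the scatter). For compound 4 the estimated value is 16%, with an expected range of 4% to 40%.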

Compound 4, percent of the compound remaining: 18%
Compound 4: the middle estimate sits 2 percentage points below what was measured; low and high end bracket the measured number.
By their numbers in this assay, from the lowest: compound 2; then compounds 4 and 3 (each within the scatter of the next); then compound 1.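

Working from this assay, the added carbon of (4-hydroxycyclohexyl)methyl on this nitrogen does not separate the new compound from its closest cyclohexyl neighbour, with a number 7 percentage points lower from compound 3 to compound 4 (within the scatter), while the other cyclohexyl compound lies lower, with a number 12 percentage points higher from compound 2 to compound 4 (beyond the scatter). The distance to the cyclobutyl compound stays large, with a number 64 percentage points lower from compound 1 to compound 4 (beyond the scatter), so all three compounds with a six-membered ring sit far from compound 1, whether that ring is attached directly or through the added carbon. Nothing measured gives a cause for this result.

As far as these compounds go, it remains open whether (3-hydroxycyclobutyl)methyl on the same nitrogen would stay close to compound 1 at 82%. Also open, from the compounds shown here alone, is how an amine or a carboxylic acid in place of the hydroxyl on the six-membered ring would read here.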